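This account rests on a few compounds, and the source may have more. Where it says the series, first, only, none or still open, it means among the compounds named here.

Compound 1 `O=C(CCc1cccc2c1B(O)OC2)NC1CCCCC1` gives > 100000 nM in a functional assay on SK-OV-3 cells (Homo sapiens) for antiproliferative activity, read by MTT assay, with a stated time of 72 h; on this read-out higher numbers stand for weaker inhibition and lower numbers for stronger inhibition. Compound 2 `C#Cc1ccc(NC(=O)CCc2cccc3c2B(O)OC3)cc1` gives 6300 nM in this assay.

The value of compound 1 is a limit of the assay and not a number: it sits at the limit of > 100000 nM in this assay, at which 1 of the 2 values shown sits. Compound 3 `O=C(CCc1cccc2c1B(O)OC2)Nc1cccc(Br)c1` differs from compound 1 by 3-bromophenyl in place of cyclohexyl on an amide-type nitrogen. For the measured compounds named here, no measured pair shows this change, so the size of the step is a matter of expectation. Compound 2, which gives 6300 nM in this assay, suggests that an aromatic amide partner reaches a measurable number. The step from compound 1 to compound 3 is expected to run toward stronger inhibition, beyond the scatter, at an at least 11-fold lower number from compound 1 to compound 3 (1.04 log units; beyond the scatter). Compound 3 is expected near 9000 nM, between 2500 nM and 35000 nM.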

Compound 3, half-maximal inhibitory concentration: 540 nM
Estimate against measurement, compound 3: 17-fold (1.22 log units) above, outside the stated range (below it).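

In this assay, 3-bromophenyl in place of cyclohexyl on an amide-type nitrogen gives an at least 180-fold lower number from compound 1 to compound 3 (2.26 log units; beyond the scatter), a large step beyond the scatter. The value of compound 1 is a limit and not a number: the limit of > 100000 nM in this assay, at which 1 of the 3 values shown sits. Compound 2 had already given 6300 nM with an aromatic amide partner, and compound 3, at 540 nM, now shows a second such partner reaching a measurable number. The compounds shown leave open how much of the step belongs to the aromatic ring and how much to the bromine. A plain phenyl on this nitrogen would bear on that question.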